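The compounds below may be only part of what the source reports. "The series", "measured", "known", "first", "only" and "open" are said of these compounds alone.

Working notes on the series sharing the core of compound 1 `CCCCn1ccnc1-c1cc(OC)c(OC)c(OC)c1`, read in a functional assay on HCT-15 cells (Homo sapiens) for antiproliferative activity, read by MTT assay, with a stated time of 72 h; on this read-out lower numbers stand for stronger inhibition and higher numbers for weaker inhibition. Compound 1 gives > 100000 nM, which is a limit of the assay and not a number. Compound 2 `COc1cc(-c2nccn2-c2cccc(C)c2)cc(OC)c1OC` gives 1600 nM. Compound 3 `COc1cc(-c2nccn2-c2ccc(Br)cc2)cc(OC)c1OC` gives 11700 nM, the higher of the two true numbers in this assay.

The next change leads to compound 4 `COc1ccc(-n2ccnc2-c2cc(OC)c(OC)c(OC)c2)cc1`: methoxy in place of bromo on an aromatic carbon. This places methoxy in place of bromo on an aromatic carbon, para to a large group.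

Two measured steps show what replacing butyl can do: an at least 62-fold lower number from compound 1 to compound 2 (1.79 log units; beyond the scatter) and an at least 8.5-fold lower number from compound 1 to compound 3 (0.93 log units; beyond the scatter), both starting from the limit. For the measured compounds named here, the closer guide is a 7.3-fold higher number from compound 2 to compound 3 (0.86 log units; beyond the scatter), the only measured step between two substituted phenyl groups, and it is modest. Going by the values given here, no measured step changes the para substituent alone, so the direction is weakly founded. Since compound 3 at 11700 nM lies at the upper end of the two substituted phenyl compounds, a modest move toward a lower number is expected, with a wide margin.

The estimated change is a 3.9-fold lower number from compound 3 to compound 4 (0.59 log units; beyond the scatter). For compound 4 the expected value in this assay is 3000 nM, with an estimated range from 400 nM to 20000 nM.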

Compound 4, half-maximal inhibitory concentration: 1300 nM
The estimate for compound 4 lay 2.3-fold (0.36 log units) above the measured number, and the stated range covers the measured number.
By their numbers in this assay, from the lowest: compounds 4 and 2 (each within the scatter of the next); then compound 3. At a limit, above all of these: compound 1.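

In this assay, for the compounds shown here, methoxy in place of bromo on an aromatic carbon, para to a large group, gives a 9.0-fold lower number from compound 3 to compound 4 (0.95 log units; beyond the scatter), the first measured step in which this substituent alone changes. The other comparison between substituted phenyl groups gives a 1.2-fold lower number from compound 2 to compound 4 (0.09 log units; within the scatter), which leaves 4-methoxyphenyl and 3-methylphenyl on the aromatic nitrogen indistinguishable here, while 4-bromophenyl is the one of the three that stands apart from both others. Compound 1 gives > 100000 nM, a limit of the assay and not a number, so an at least 76-fold lower number from compound 1 to compound 4 (1.88 log units; beyond the scatter) marks only a bound on what replacing butyl does: the limit of > 100000 nM in this assay, at which 1 of the 4 values shown sits.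

On these data alone, only bromo and methoxy are compared at this place, so it remains open whether a hydroxyl, an amine or a carboxylic acid there would read like methoxy or like bromo, and where the plain phenyl group would fall. The methyl of compound 2 and the methoxy of compound 4 also sit at different places on the phenyl ring, so the compounds shown cannot separate the identity of either group from where it sits.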